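Swapping Diethylamino for Methoxy on a Weak Antagonist

The source may report more compounds than this note shows. Statements on the series, on what has been measured and on what is new or still open speak of the compounds shown alone.

Measured so far:
compound 1, `CCN1CCN(CCCn2cnc3c(N4CCN(C(=O)C5CCCC5)CC4)nc(NCc4ccc(N(CC)CC)cc4)nc32)CC1`: 8800 nM
compound 2, `CCN1CCN(CCCn2cnc3c(N4CCN(CC)CC4)nc(NCc4ccc(N(CC)CC)cc4)nc32)CC1`: 440 nM
compound 3, `CCN1CCN(CCCn2cnc3c(N4CCN(C5CCCC5)CC4)nc(N)nc32)CC1`: 280 nM

All three were tested in an assay on HEK293 cells for antagonist activity at Toll-like receptor 9 (Homo sapiens), read by spectrophotometry; on this read-out lower numbers stand for stronger inhibition and higher numbers for weaker inhibition. Compound 1 stands highest of the three numbers, so it is the weakest inhibitor shown. Its nearest neighbour is compound 2, reached by a single change: a 20-fold lower number from compound 1 to compound 2 (1.30 log units; beyond the scatter). Going by the values given here, compound 3, with 280 nM, lies further away still, but it differs from compound 1 in more than one place, so no single step connects the two.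

The compound now in question is compound 4, `CCN1CCN(CCCn2cnc3c(N4CCN(C(=O)C5CCCC5)CC4)nc(NCc4ccc(OC)cc4)nc32)CC1`. It differs from compound 1 by methoxy in place of diethylamino on an aromatic carbon. Among the compounds with values here, no measured step bears on this position: the one step known concerns the amine nitrogen in a ring, not the aromatic ring, and compound 3 carries no benzyl group at all. With nothing to point either way, the expectation for compound 4 is a step of no change at the digits printed from compound 1 to compound 4 (within the scatter), that is none beyond the scatter, though with wide uncertainty. Compound 4 is therefore estimated at 8800 nM, between 2500 nM and 30000 nM.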

Compound 4, half-maximal inhibitory concentration: > 30000 nM
Compound 4: only a limit was reported (the forecaster's own chance of this, stated with the estimate: 10%); middle value at least 3.4-fold (0.53 log units) away from the limit.
By their numbers in this assay, from the lowest: compounds 3 and 2 (each within the scatter of the next); then compound 1. At a limit, above all of these: compound 4.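

The earlier compounds shown here said nothing about the group on the aromatic ring, and this change shows that it matters: replacing diethylamino with methoxy gives an at least 3.4-fold higher number from compound 1 to compound 4 (0.53 log units; beyond the scatter). Compound 4 is reported only as a limit of the assay: the limit of > 30000 nM in this assay, at which 1 of the 4 values shown sits. As far as these compounds go, the full size of the loss therefore stays unknown, but of these two groups diethylamino gives the stronger inhibition, even on a compound that already inhibits weakly with cyclopentylcarbonyl on the ring nitrogen.

The compounds shown leave open whether the same swap would cost as much in compound 2, which carries ethyl in that place. They also leave open how dimethylamino, pyrrolidine or a plain hydroxyl would read on this ring, and so whether the nitrogen of diethylamino or its two ethyl chains count for more.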